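This account rests on a few compounds, and the source may have more. Where it says the series, first, only, none or still open, it means among the compounds named here.

In a functional assay on the whole organism for inhibition, with Felis catus as the target, with a stated time of 30 min (a lower number here means that less compound is needed, a higher number that more compound is needed for the effect), compound 1 (`Cc1ccccc1OCCNCC(O)COc1ccccc1`) gives 0.031 mg/kg and compound 2 (`OC(CNCCOc1ccc(F)cc1)COc1ccccc1`) gives 0.029 mg/kg so that the two stand level within the scatter. Within the data shown here, the only measured step is a 1.1-fold lower number from compound 1 to compound 2 (0.03 log units; within the scatter) and it stays within the scatter. That step puts 4-fluorophenyl in place of 2-methylphenyl on an oxygen on a saturated carbon, so one aromatic group replaces another.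

Compound 3 (`CCOCCNCC(O)COc1ccccc1`) changes the same place further: ethyl in place of 4-fluorophenyl on an oxygen on a saturated carbon with ethyl in place of 4-fluorophenyl. Among the measured compounds shown here, no measured step removes the aromatic ring, so the flat step between compound 1 and compound 2 gives only weak guidance here. A moderate move to a higher number in this assay is expected, with wide uncertainty. The estimated change is a 3.4-fold higher number from compound 2 to compound 3 (0.54 log units; beyond the scatter) for this pair. For compound 3 the expected value is 0.1 mg/kg within an estimated range of 0.03 mg/kg to 0.4 mg/kg in this series.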

Compound 3, dose for half-maximal effect: 0.047 mg/kg
Compound 3: the middle estimate sits 2.1-fold (0.33 log units) above what was measured, within the range that was stated.
By their numbers in this assay, from the lowest: compounds 2, 1 and 3 (each within the scatter of the next).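

With ethyl on an oxygen on a saturated carbon, the aromatic ring at this place is gone, a change that the step between compound 1 and compound 2 did not test. In this assay this change stays within the scatter from either aromatic starting point (a 1.6-fold higher number from compound 2 to compound 3 (0.21 log units; within the scatter)) (a 1.5-fold higher number from compound 1 to compound 3 (0.18 log units; within the scatter)), so among these three compounds a six-membered aromatic ring at this place is not required for a number at this level, and the smaller ethyl serves as well as 4-fluorophenyl or 2-methylphenyl. Nothing available accounts for this tolerance or links it to any property of the groups.

The compounds shown leave open whether a longer chain such as butyl, or a chain ending in an amine or a carboxylic acid, would also stand level at this place. They also leave open how far the group on this oxygen can shrink, for instance to methyl, before the number moves beyond the scatter.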